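Swapping a pyrimidinyl for a carbamate on a GIP receptor agonist

The source may report more compounds than this note shows. Statements on the series, on what has been measured and on what is new or still open speak of the compounds shown alone.

Compound 1, `CS(=O)(=O)c1ccc2c(c1)CCN2c1ncnc2c(C3CCN(c4ncccn4)CC3)coc12`, is measured in a functional assay on cells for agonist activity at Glucose-dependent insulinotropic receptor (Homo sapiens), read by a luciferase reporter, with a stated time of 4 h (a lower number here means a smaller maximal response, a higher number a larger maximal response), and gives 196%. Among the two compounds measured, compound 1 stands highest; its nearest neighbour is compound 2, `CC(C)(C)OC(=O)N1CCC(c2csc3c(Nc4ccc(S(C)(=O)=O)cc4F)ncnc23)CC1`, which in this assay reaches 82%, a gap well beyond the usual scatter. Compound 2 shares neither the shared core of compound 1 nor a single-point relation to it, so the two values only show that one compound reaches a large maximal response while the other reaches a smaller one.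

Compound 3, `CC(C)(C)OC(=O)N1CCC(c2coc3c(N4CCc5cc(S(C)(=O)=O)ccc54)ncnc23)CC1`, has not yet been measured. It differs from compound 1 in one place: tert-butoxycarbonyl in place of pyrimidin-2-yl on an amine nitrogen in a ring. Compound 2 also carries tert-butoxycarbonyl on an amine nitrogen in a ring and gives 82%, but its other differences from compound 1 leave the effect of that group alone unknown.

Compound 3 is therefore expected to give a moderate downward step, a number 46 percentage points lower from compound 1 to compound 3 (beyond the scatter), with a wide spread. In this assay compound 3 is estimated at 150%, in a range from 90% to 200%.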

Compound 3, largest response reached (Emax), in percent of the reference or control that the assay uses: 123%
Compound 3: middle estimate off by 27 percentage points, on the high side; low and high end bracket the measured number.
By their numbers in this assay, from the lowest: compound 2; then compound 3; then compound 1.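

For the compounds shown here, putting tert-butoxycarbonyl in place of pyrimidin-2-yl on an amine nitrogen in a ring gives, in this assay, a number 73 percentage points lower from compound 1 to compound 3 (beyond the scatter) with nothing else in the molecule altered, so this is the first reading of that change on its own and it shows that the group on this nitrogen matters for the maximal response. The aromatic ring is not a requirement for a sizeable response, since compound 3, which has no ring in this group, still gives 123% in this assay and so keeps part of the response of compound 1. No measurement at hand speaks to why the response falls with this change.

Going by these compounds, whether a pyridin-2-yl ring, an acetyl group or the bare ring amine on this nitrogen would fall nearer to compound 1 or to compound 3 remains open. On these data alone, it is also open whether the same exchange would shift the response by a similar size on the core of compound 2, as this single pair rests on one core only.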